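Compound 3 to compound 4: the carbonyl link goes

The compounds below may be only part of what the source reports. "The series", "measured", "known", "first", "only" and "open" are said of these compounds alone.

In a functional assay on MDA-MB-231 cells (Homo sapiens) for antiproliferative activity, read by MTT assay, with a stated time of 72 h (on this read-out lower numbers stand for stronger inhibition and higher numbers for weaker inhibition), compound 1 `CC(=O)O[C@H]1CC[C@]2(C)[C@H](CC[C@@](C)(O)[C@H]2CC[C@@H]2C(C)=CC[C@H]3[C@H](CC[C@]3(C)O)C2(C)C)OC1(C)C` gives 38000 nM and compound 2 `CC1=CC[C@H]2[C@H](CC[C@]2(C)O)C(C)(C)[C@@H]1CC[C@H]1[C@]2(C)CC[C@H](OC(=O)CCC(=O)O)C(C)(C)O[C@H]2CC[C@@]1(C)O` gives 27900 nM and compound 3 `CC1=CC[C@H]2[C@H](CC[C@]2(C)O)C(C)(C)[C@@H]1CC[C@H]1[C@]2(C)CC[C@H](OC(=O)c3ccc(C)cc3)C(C)(C)O[C@H]2CC[C@@]1(C)O` gives 33400 nM on the same core. Compound 3 stands within the scatter of both other compounds, as the two steps (a 1.1-fold lower number from compound 1 to compound 3 (0.06 log units; within the scatter)) and (a 1.2-fold higher number from compound 2 to compound 3 (0.08 log units; within the scatter)) show.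

Compound 4 `CC1=CC[C@H]2[C@H](CC[C@]2(C)O)C(C)(C)[C@@H]1CC[C@H]1[C@]2(C)CC[C@H](OCc3ccccc3)C(C)(C)O[C@H]2CC[C@@]1(C)O` is the next case. The difference is benzyl in place of (4-methylphenyl)carbonyl on an oxygen on a saturated carbon.

For the measured compounds named here, no measured step removes the carbonyl, so the series holds no direct measure of this change. Going by the values given here, the nearest evidence is the exchange of groups on the carbonyl carbon, where all three steps stay within the scatter, including the one between compound 1 and compound 2 (a 1.4-fold lower number from compound 1 to compound 2 (0.13 log units; within the scatter)). Among the compounds with values here, this flat picture rests on only three compounds, and it supports a cautious expectation of no step beyond the scatter in this assay, with no firm direction. The expected step is small (a 1.2-fold lower number from compound 3 to compound 4 (0.08 log units; within the scatter)), and the range is kept wide for the untested loss of the carbonyl. In this assay compound 4 is estimated at 28000 nM within an expected range from 12000 nM to 55000 nM for this read-out.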

Compound 4, half-maximal inhibitory concentration: 29100 nM
Estimate against measurement, compound 4: 1.0-fold (0.02 log units) below; the measured number falls inside the stated range.
By their numbers in this assay, from the lowest: compounds 2, 4, 3 and 1 (each within the scatter of the next).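

In this assay the carbonyl on this oxygen can be replaced without a step beyond the scatter, a change the earlier exchanges on the carbonyl carbon did not test: benzyl in place of (4-methylphenyl)carbonyl gives (a 1.1-fold lower number from compound 3 to compound 4 (0.06 log units; within the scatter)). The same holds when benzyl is read against the other two esters, with (a 1.0-fold higher number from compound 2 to compound 4 (0.02 log units; within the scatter)) and (a 1.3-fold lower number from compound 1 to compound 4 (0.12 log units; within the scatter)), so the ester link is not required for the numbers seen at this position in this assay, and all four groups on the oxygen, with or without a carbonyl and with or without an aromatic ring, remain indistinguishable. No supporting data bear on why this position stays so flat in the series.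

The compounds shown leave open whether any group on this oxygen can move the number beyond the scatter, for example a bare hydroxyl with no substituent, a chain ending in an amine, or a longer alkyl chain. They also leave open whether the flat picture is particular to this oxygen, since every change shown sits there and the rest of the shared core stays the same.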